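This account rests on a few compounds, and the source may have more. Where it says the series, first, only, none or still open, it means among the compounds named here.

The three measured compounds share one core and differ only in the group carried on an aromatic nitrogen of the triazole. Compound 1, `O[C@H](COCCOC[C@@H](O)Cc1cn(-c2cccs2)nn1)Cc1ccc(-c2ccccc2)cc1`, carries thiophen-2-yl there and in a functional assay on HCT-116 cells (Homo sapiens) for inhibition, read by MTT assay, with a stated time of 72 h (on this read-out lower numbers stand for stronger inhibition of growth and higher numbers for weaker inhibition of growth), compound 1 gives 33400 nM. Compound 2, `O=C1COc2ccc(-n3cc(C[C@H](O)COCCOC[C@@H](O)Cc4ccc(-c5ccccc5)cc4)nn3)cc2N1`, gives 42500 nM, and the two stand close: a 1.3-fold higher number from compound 1 to compound 2 (0.10 log units; within the scatter). Compound 3, `O[C@H](COCCOC[C@@H](O)Cc1cn(Cc2ccc(C(F)(F)F)cc2)nn1)Cc1ccc(-c2ccccc2)cc1`, carries 4-(trifluoromethyl)benzyl and gives 2500 nM, the lowest of the three numbers; the gaps to its neighbours are a 13-fold lower number from compound 1 to compound 3 (1.13 log units; beyond the scatter) and a 17-fold lower number from compound 2 to compound 3 (1.23 log units; beyond the scatter), both well beyond the scatter.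

Compound 4, `O=c1[nH]c2ccc(-n3cc(C[C@H](O)COCCOC[C@@H](O)Cc4ccc(-c5ccccc5)cc4)nn3)cc2s1`, has not yet been measured. It differs from compound 3 in one place: a group of 10 heavy atoms (7 carbon, 1 nitrogen, 1 oxygen, 1 sulfur; one five-membered aromatic ring with 2 hetero atoms, one six-membered aromatic ring of carbon only) in place of a group of 11 heavy atoms (8 carbon, 3 fluorine; one six-membered aromatic ring of carbon only), on an aromatic nitrogen. Among the compounds with values here, the steps that bear on this change are the two that brought the trifluoromethylbenzyl in, each of which lowered the number by a large margin. Compound 4 now exchanges that benzyl for an aryl group bearing nitrogen, oxygen and sulfur, closer in kind to the group of compound 2 than to the benzyl of compound 3. Compound 4 is therefore expected to move back up, by roughly a 12-fold higher number from compound 3 to compound 4 (1.08 log units; beyond the scatter). The estimate for compound 4 is 30000 nM, with a range from 8000 nM to 100000 nM.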

Compound 4, concentration for 50% growth inhibition: 9200 nM
Compound 4: middle estimate off by 3.3-fold (0.51 log units), on the high side, within the range that was stated.
By their numbers in this assay, from the lowest: compound 3; then compound 4; then compounds 1 and 2 (each within the scatter of the next).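

In this assay, the result shows that the group on this aromatic nitrogen need not be 4-(trifluoromethyl)benzyl for the number to fall clearly below those of compounds 1 and 2, as the two steps to the new group show (a 3.6-fold lower number from compound 1 to compound 4 (0.56 log units; beyond the scatter); a 4.6-fold lower number from compound 2 to compound 4 (0.66 log units; beyond the scatter)). The two-ring group of compound 4 has no benzyl carbon and no fluorine, yet it recovers part of the gap that separated compounds 1 and 2 from compound 3, although 4-(trifluoromethyl)benzyl still gives the lower number (a 3.7-fold higher number from compound 3 to compound 4 (0.57 log units; beyond the scatter)). It also shows that groups of similar size at this place can differ beyond the scatter, since compounds 2 and 4 carry two-ring groups of nearly the same heavy-atom count, but no measurement given here accounts for any of these differences.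

The compounds shown do not separate the benzyl carbon from the trifluoromethyl group, so plain benzyl and 4-(trifluoromethyl)phenyl would each be needed to tell which of the two goes with the lowest number. As far as these compounds go, the role of the hydrogen on the ring nitrogen of compound 4 also stays open, and a methyl group on that nitrogen would test it.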